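Swapping a bromophenylamino group for propyl on the amide

A few compounds are considered here, and "the series" means these few. Any claim that something is new, unique, unknown or untested is made for them only; others in the source may bear on it.

Compound 1 `NNC(=O)c1c(NC(=O)NS(=O)(=O)c2ccccc2)sc2c1CCCCC2` gives 30300 nM in a functional assay on cells (Leukemia cell, Homo sapiens) for inhibition, with a stated time of 48 h; a higher number here means a weaker inhibitor of growth, a lower number a stronger inhibitor of growth. Compound 2 `CN1CCN(C(=O)c2c(NC(=O)NS(=O)(=O)c3ccccc3)sc3c2CCCCC3)CC1` reaches only the limit of this assay, > 100000 nM. Compound 3 `O=C(Nc1sc2c(c1C(=O)NNc1ccc(Br)cc1)CCCCC2)NS(=O)(=O)c1ccccc1` likewise gives only a limit in this assay, > 100000 nM, so its position is known merely as weaker than a number; it shares this limit with compound 2 (the limit of > 100000 nM in this assay, at which 2 of the 3 values shown sit). Compound 4 `CCCNC(=O)c1c(NC(=O)NS(=O)(=O)c2ccccc2)sc2c1CCCCC2` differs from compound 3 in one place (propyl in place of (4-bromophenyl)amino on an amide-type nitrogen). The step that bears on this is an at least 3.3-fold higher number from compound 1 to compound 3 (0.51 log units; beyond the scatter), where adding 4-bromophenyl took a measured number down to a limit; removing that group in compound 4 is expected to reverse part of that loss. Compound 4 is therefore estimated at 50000 nM, spanning 15000 nM to 150000 nM, meaning an expected step of an at least 2.0-fold lower number from compound 3 to compound 4 (0.30 log units; that floor lies within the scatter).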

Compound 4, concentration for 50% growth inhibition: 42200 nM
Compound 4: middle estimate off by 1.2-fold (0.07 log units), on the high side; low and high end bracket the measured number.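

A plain propyl on the amide-type nitrogen keeps growth inhibition measurable in this assay, with an at least 2.3-fold lower number from compound 3 to compound 4 (0.37 log units; beyond the scatter), and propylamino in place of 4-methylpiperazin-1-yl on the carbonyl carbon gives an at least 2.3-fold lower number from compound 2 to compound 4 (0.37 log units; beyond the scatter). Both steps start from a limit: the limit of > 100000 nM in this assay, at which 2 of the 4 values shown sit. Propyl in place of amino gives a 1.4-fold higher number from compound 1 to compound 4 (0.14 log units; within the scatter), so the two groups cannot be told apart here.

As far as these compounds go, whether a longer chain such as butyl would lower the number remains open. So does whether a plain phenylamino group, without the bromine, would also reach the limit seen for compound 3.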